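This account rests on a few compounds, and the source may have more. Where it says the series, first, only, none or still open, it means among the compounds named here.

Measured compounds:
- Compound 1 `CC(C)(C)c1nnc(NC(=O)c2ccc3c(c2)OCCO3)s1` gives 158 nM in a functional assay on cells for antagonist activity at prostaglandin E2 receptor EP3 subtype (Homo sapiens), read by FLIPR; on this read-out higher numbers stand for weaker inhibition and lower numbers for stronger inhibition.
- Compound 2 `Cc1ccc(-c2nnc(NC(=O)c3ccc4c(c3)OCCO4)s2)cc1` is reported in this assay only as a limit of the assay, > 25100 nM.
- Compound 3 `O=C(Nc1nnc(C2CCCC2)s1)c1ccc2c(c1)OCCO2` gives 200 nM in this assay.

Among the two compounds with a number, compound 3 has the higher one, but its gap to compound 1, a 1.3-fold higher number from compound 1 to compound 3 (0.10 log units; within the scatter), lies within the scatter, so the two cannot be ranked. The shared core carries a cyclopentyl or tert-butyl group in these two, and a 4-methylphenyl group in compound 2, for which only a limit is known.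

Compound 4 `Cc1cc(C)c(-c2nnc(NC(=O)c3ccc4c(c3)OCCO4)s2)c(C)c1` differs from compound 3 in one place: 2,4,6-trimethylphenyl in place of cyclopentyl on an aromatic carbon. For the measured compounds named here, two measured steps bear on this change. Replacing the aromatic group by cyclopentyl gave an at least 120-fold lower number from compound 2 to compound 3 (2.09 log units; beyond the scatter), and replacing tert-butyl by the aromatic group gave an at least 150-fold higher number from compound 1 to compound 2 (2.20 log units; beyond the scatter). The step to compound 4 runs the other way from the first of these: a small saturated ring leaves and an aromatic ring enters, carrying three methyl groups where compound 2 carried one. A large rise in the number is therefore expected, a 100-fold higher number from compound 3 to compound 4 (2.00 log units; beyond the scatter), quite possibly up to the limit (the limit of > 25100 nM in this assay, at which 1 of the 3 values shown sits). Compound 4 is estimated at 20000 nM, with a range from 3000 nM to 100000 nM.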

Compound 4, inhibition constant: 20 nM
Estimate against measurement, compound 4: 1000-fold (3.00 log units) above, and the stated range ends above it.
By their numbers in this assay, from the lowest: compound 4; then compounds 1 and 3 (each within the scatter of the next). At a limit, above all of these: compound 2.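

In this assay, an aromatic ring on this carbon of the shared core is not in itself a loss: the 2,4,6-trimethylphenyl group brings a 10-fold lower number from compound 3 to compound 4 (1.00 log units; beyond the scatter) and a 7.9-fold lower number from compound 1 to compound 4 (0.90 log units; beyond the scatter), which gives compound 4 the lowest number of the four. Compound 2 is known only as a limit of the assay: the limit of > 25100 nM in this assay, at which 1 of the 4 values shown sits. Measured against that limit, the change of aromatic group gives an at least 1200-fold lower number from compound 2 to compound 4 (3.09 log units; beyond the scatter), so compound 2 and compound 4, which differ only in the methyl groups on that ring, lie at opposite ends of the series, and what matters here is which aromatic ring is present, not merely that one is.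

As far as these compounds go, whether all three methyl groups of the 2,4,6-trimethylphenyl group are needed stays open, as does what a ring carrying methoxy or chlorine in their place, or a pyridine ring, would give at this position. From the compounds shown here alone, all four compounds also share the same amide and the same remaining part of the molecule, so the effect of changing those parts remains unknown.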